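Ring substituent changes on the shared core

The compounds below may be only part of what the source reports. "The series", "measured", "known", "first", "only" and "open" are said of these compounds alone.

The shared core is seen in compound 1, `O=C(O)Cc1sc(C(c2ccc(F)cc2)c2ccc(F)cc2)nc1-c1ccnc(F)c1`, which in an in vitro functional assay on HEK285-7 cells for antagonist activity at prostaglandin D2 receptor 2 (Homo sapiens), read by BRET and beta-arrestin recruitment (on this read-out lower numbers stand for stronger inhibition and higher numbers for weaker inhibition), gives 4.7 nM. Compound 3, `O=C(O)Cc1sc(C(c2ccc(F)cc2)c2ccc(F)cc2)nc1-c1cccc(F)c1`, gives 18 nM in this assay, and the step of a 3.8-fold higher number from compound 1 to compound 3 (0.58 log units; beyond the scatter) is modest. Compound 2, `NS(=O)(=O)c1ccc(-c2nc(C(c3ccc(F)cc3)c3ccc(F)cc3)sc2CC(=O)O)cc1`, reaches only the limit of this assay and gives > 100000 nM. Of the two numbers, compound 3 stands highest, with compound 1 nearest to it.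

Compound 4, `Cc1cc(-c2nc(C(c3ccc(F)cc3)c3ccc(F)cc3)sc2CC(=O)O)cnc1N`, is not yet measured. The change from compound 3 is 6-amino-5-methylpyridin-3-yl in place of 3-fluorophenyl on an aromatic carbon. Among the compounds with values here, two measured steps bear on this position: the modest 3.8-fold higher number from compound 1 to compound 3 (0.58 log units; beyond the scatter), and the large at least 5500-fold lower number from compound 2 to compound 3 (3.74 log units; beyond the scatter), where the group that leaves carries a hydrogen-bond donor and acceptors, as the group entering in compound 4 does. The step is therefore expected to raise the number, with its size uncertain between these two cases, a 14-fold higher number from compound 3 to compound 4 (1.14 log units; beyond the scatter). Compound 4 is estimated at 250 nM in this assay, expected to fall between 25 nM and 5000 nM.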

Compound 4, half-maximal inhibitory concentration: > 100000 nM
Compound 4 was reported as a limit; the forecaster's own chance of this, stated with the estimate: 20%; at least 400-fold (2.60 log units) between middle value and limit.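

In this assay, 6-amino-5-methylpyridin-3-yl gives an at least 5500-fold higher number from compound 3 to compound 4 (3.74 log units; beyond the scatter), and an at least 21000-fold higher number from compound 1 to compound 4 (4.32 log units; beyond the scatter). The drop at this position is therefore not peculiar to 4-sulfamoylphenyl: among the listed compounds, a second group with a hydrogen-bond donor and acceptors also ends at the assay limit, whereas 3-fluorophenyl, with no hydrogen-bond donor, stays measurable. Compound 2 and compound 4 each give a limit and not a number, so the step between them cannot be read and no order between them follows: the limit of > 100000 nM in this assay, at which 2 of the 4 values shown sit.

The compounds shown leave open whether the amine or the methyl of compound 4 accounts for the loss. A pyridin-3-yl group carrying only the amine, or only the methyl, would separate the two.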